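The compounds below may be only part of what the source reports. "The series", "measured", "known", "first", "only" and "open" are said of these compounds alone.

In a functional assay on THP-1 cells (Homo sapiens) for inhibition, read by ELISA, tested at 10 uM (on this read-out higher numbers stand for more inhibition at the one concentration tested (going by the name of the read-out) and lower numbers for less inhibition), compound 2 `CC(=O)OCCCc1cnc2ncnn2c1` gives 45%, the higher of the two numbers seen so far. Its only companion, compound 1 `Cc1nn(C)c2ncc(CCCO)cc12`, gives 27% in this assay, a gap beyond the usual scatter; the two differ in more than one place, so that gap says nothing about any single change. Compound 3 `OCCCc1cnc2ncnn2c1` has not yet been measured. It differs from compound 2 by hydrogen in place of acetyl on an oxygen on a saturated carbon. Among the measured compounds shown here, no measured pair shows this change, so its step is unknown. Compound 3 is expected to give 35% in this assay, within 15% to 55%. The expected step is a number 10 percentage points lower from compound 2 to compound 3 (within the scatter), a small loss or none beyond the scatter.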

Compound 3, a percentage reported as inhibition, at one concentration (the size of the read-out at that concentration, not a potency): 43%
Beside the measured number, compound 3's estimate is 8 percentage points below it, and the stated range covers the measured number.
By their numbers in this assay, from the lowest: compound 1; then compounds 3 and 2 (each within the scatter of the next).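

In this assay, among the compounds shown here, putting hydrogen in place of acetyl on this oxygen gives a number 2 percentage points lower from compound 2 to compound 3 (within the scatter) and offers the first comparison here of compounds that differ in one place. At this position, acetoxy and hydroxy therefore cannot be told apart, and the acetyl is not needed to keep this level of inhibition. Nothing measured here bears on the reason for this result. Still open, from the compounds shown here alone, is whether an amine or a carboxylic acid in place of the hydroxy, or a longer chain, would hold this level. Also open, going by these compounds, is whether the same change would behave alike on the core of compound 1.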